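The source may report more compounds than this note shows. Statements on the series, on what has been measured and on what is new or still open speak of the compounds shown alone.

Working notes on the indole-carboxamide series and its behaviour in an ADME assay on Vero cells (Chlorocebus sabaeus) for cytotoxicity, with a stated time of 7 days; on this read-out higher numbers stand for lower toxicity in this test and lower numbers for higher toxicity in this test.

Compound 1 `COc1ccc2[nH]c(C(=O)N3CC(=O)N(Cc4ccccc4)[C@@H](CN4CCC5(CC4)CC5)C3)cc2c1` gives 17100 nM in this assay. Compound 2 `COc1cccc(CN2C(=O)CN(C(=O)c3cc4cc(OC)ccc4[nH]3)C[C@@H]2CCc2ccccc2)c1` gives 4500 nM in this assay, a lower number than compound 1 by a gap that lies beyond the usual scatter. Compound 3 `COc1ccc2[nH]c(C(=O)N3CC(=O)N(Cc4cccc(OC(F)F)c4)[C@@H](CN4CCC(c5ccccn5)CC4)C3)cc2c1` reaches only the limit of this assay, > 100000 nM, not a number; this is the case noted as the limit of > 100000 nM in this assay, at which 1 of the 3 values shown sits. Among the two numbers at hand, compound 1 therefore stands highest.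

Compound 4 `COc1ccc2[nH]c(C(=O)N3CC(=O)N(Cc4ccccc4)[C@@H](CN4CC5CC5C4)C3)cc2c1` has not yet been measured in this assay. Against compound 1 it carries a group of 6 heavy atoms (5 carbon, 1 nitrogen; one three-membered non-aromatic ring of carbon only, one five-membered non-aromatic ring with 1 hetero atom) in place of a group of 8 heavy atoms (7 carbon, 1 nitrogen; one three-membered non-aromatic ring of carbon only, one six-membered non-aromatic ring with 1 hetero atom), on a saturated chain carbon bound to a saturated ring carbon. For the measured compounds named here, no measured pair of compounds in the set differs in this one place, so no measured step is available as a guide for the change from compound 1 to compound 4. The expectation is a step of no more than the scatter in either direction from compound 1 to compound 4, a 1.2-fold higher number from compound 1 to compound 4 (0.07 log units; within the scatter). On that basis compound 4 is estimated at 20000 nM in this assay, with a range from 7000 nM to 60000 nM.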

Compound 4, half-maximal cytotoxic concentration: 13800 nM
Compound 4: middle estimate off by 1.4-fold (0.16 log units), on the high side; the measured number falls inside the stated range.
By their numbers in this assay, from the lowest: compound 2; then compounds 4 and 1 (each within the scatter of the next). At a limit, above all of these: compound 3.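

For the compounds shown here, the step of a 1.2-fold lower number from compound 1 to compound 4 (0.09 log units; within the scatter) in this assay gives the first reading at this position, on a saturated chain carbon bound to a saturated ring carbon. In this one pair, the group with one five-membered non-aromatic ring with 1 hetero atom and the group with one six-membered non-aromatic ring with 1 hetero atom give values within the scatter of each other, with the three-membered carbon ring present in both. No measured property shown here bears on this step.

On these data alone, it remains open whether a group of another kind at this position, such as a carboxylic acid or an open-chain dimethylamine, would give a step beyond the scatter. Compound 3 differs from compound 1 in more than one place, so its limit cannot be assigned to any single group.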